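Sulfonyl for benzyl on the ring nitrogen: cytotoxicity outlook

The source may report more compounds than this note shows. Statements on the series, on what has been measured and on what is new or still open speak of the compounds shown alone.

Compound 1, `Cc1cc(C)cc(Cn2c(SCC(=O)Nc3ccccc3[N+](=O)[O-])nc3ccccc32)c1`: 194000 nM
Compound 2, `Cc1cc(C)cc(Cn2c(SCC(=O)Nc3ccccc3[N+](=O)[O-])nc3ccc(Cl)cc32)c1`: 131000 nM

In an ADME assay on MT4 cells (Homo sapiens) for cytotoxicity (a higher number here means that more compound is tolerated, a lower number that less compound is tolerated), compound 1 gives 194000 nM. Compound 2, which carries chloro in place of hydrogen on an aromatic carbon, gives 131000 nM in this assay; the step of a 1.5-fold lower number from compound 1 to compound 2 (0.17 log units; within the scatter) is within the scatter. Of the two numbers, compound 2 stands as the lower, but its nearest neighbour, compound 1, sits within the scatter of it.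

Compound 3, `Cc1cc(C)cc(S(=O)(=O)n2c(SCC(=O)Nc3ccccc3[N+](=O)[O-])nc3ccc(Cl)cc32)c1`, has not been measured. It differs from compound 2 by (3,5-dimethylphenyl)sulfonyl in place of 3,5-dimethylbenzyl on an aromatic nitrogen. For the measured compounds named here, the only measured step, from compound 1 to compound 2, concerns a different position and is within the scatter, so nothing measured bears directly on this change. In this assay compound 3 is therefore expected to give a number close to compound 2, with the step of a 1.0-fold lower number from compound 2 to compound 3 (0.00 log units; within the scatter) not beyond the scatter, though with wide uncertainty. The estimate for compound 3 is 130000 nM, ranging from 40000 nM to 300000 nM.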

Compound 3, half-maximal cytotoxic concentration: > 235000 nM
Compound 3: a limit, no number (the forecaster's own chance of this, stated with the estimate: 15%); middle value at least 1.8-fold (0.25 log units) from the limit.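

Placing (3,5-dimethylphenyl)sulfonyl in place of 3,5-dimethylbenzyl on the aromatic nitrogen gives an at least 1.7-fold higher number from compound 2 to compound 3 (0.25 log units; that floor lies within the scatter) in this assay, so this change at the ring nitrogen shows no loss of tolerance, a point the earlier chloro step on an aromatic carbon could not address. Its true size stays unsettled, because the read-out for compound 3 is a limit and not a number: the limit of > 235000 nM in this assay, at which 1 of the 3 values shown sits.

The compounds shown leave open how far compound 3 lies beyond that limit and whether the same sulfonyl change holds on the core of compound 1, which lacks the chloro. They also leave open whether an amine or a carboxylic acid on the aromatic ring of the sulfonyl group would keep the number this high.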